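Methylsulfanyl in place of fluoro on the aryl ether

The compounds below may be only part of what the source reports. "The series", "measured", "known", "first", "only" and "open" are said of these compounds alone.

Compound 1 `CNC[C@]1(O)Cc2ccccc2[C@@H]1Oc1ccccc1F` is measured in an in vitro assay on HEK293 cells for inhibition of sodium-dependent dopamine transporter (Homo sapiens) (a higher number here means a weaker inhibitor, a lower number a stronger inhibitor), and gives 4000 nM, the higher of the two numbers in hand. Compound 3 `CNC[C@]1(O)Cc2ccccc2[C@@H]1Oc1cccc(F)c1C` gives 3000 nM in this assay, a difference that falls within the scatter. Compound 2 `Cc1ccccc1OC1c2ccccc2CC1(O)CNCCO` is reported in this assay only as a limit, > 10000 nM (the limit of > 10000 nM in this assay, at which 1 of the 3 values shown sits), not as a number. Compound 4 `CNC[C@]1(O)Cc2ccccc2[C@@H]1Oc1ccccc1SC` differs from compound 1 by methylsulfanyl in place of fluoro on an aromatic carbon. Going by the values given here, no measured pair shows such a change, so the size of the step is uncertain; a step of less than about the usual scatter in either direction is expected, with no firm direction. Compound 4 is therefore expected to give about 3000 nM in this assay, between 800 nM and 12000 nM, a step of a 1.3-fold lower number from compound 1 to compound 4 (0.12 log units; within the scatter) from compound 1.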

Compound 4, half-maximal inhibitory concentration: > 10000 nM
Compound 4: only a limit was reported; the forecaster's own chance of this, stated with the estimate: 15%; middle value at least 3.3-fold (0.52 log units) from the limit.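

In this assay, the exchange of fluoro for methylsulfanyl on this aromatic carbon gives an at least 2.5-fold higher number from compound 1 to compound 4 (0.39 log units; beyond the scatter), the first step read at this position, and it shows that inhibition here does not survive this exchange intact. Compound 4 is reported only as a limit, so this step has a floor but no known full size: the limit of > 10000 nM in this assay, at which 2 of the 4 values shown sit.

Going by these compounds, whether the loss follows the sulfur or the added carbon stays open. So does whether methoxy or chloro on the same aromatic carbon would stay level with compound 1.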